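Removing the Chloro Group on Two Related Chromone Cores

A few compounds are considered here, and "the series" means these few. Any claim that something is new, unique, unknown or untested is made for them only; others in the source may bear on it.

The study compares two small sets of compounds sharing a sulfur-linked chromone fragment. Compound 1 `Cc1nnc(SCc2coc3ccc(Cl)cc3c2=O)o1` and compound 3 `Cc1nnc(SCc2coc3ccccc3c2=O)o1` share one core; compound 2 `Cc1cc(C)n2nc(SCc3cc(=O)c4cc(Cl)ccc4o3)nc2n1` and compound 4 `Cc1cc(C)n2nc(SCc3cc(=O)c4ccccc4o3)nc2n1` share another, and the difference between the two cores is not broken down here. In a functional assay on HEp-2 cells (Homo sapiens) for cytotoxicity, read by MTT assay, with a stated time of 72 h (a higher number here means a weaker inhibitor, a lower number a stronger inhibitor), compound 1 gives 6400 nM, and compound 3 gives 3800 nM. The change between them is hydrogen in place of chloro on an aromatic carbon, and it produced a 1.7-fold lower number from compound 1 to compound 3 (0.23 log units; within the scatter). For compound 2 the assay reports only a limit, > 25000 nM in this assay. Compound 4 has not yet been measured; it differs from compound 2 by hydrogen in place of chloro on an aromatic carbon, the same kind of change at a place described in the same words. The author expects a step that the limit leaves unreadable from compound 2 to compound 4 because a 1.7-fold lower number from compound 1 to compound 3 (0.23 log units; within the scatter) and because the limit of > 25000 nM in this assay, at which 1 of the 3 values shown sits, leaves little room to tell. For compound 4 the estimate in this assay is 30000 nM, between 12000 nM and 80000 nM.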

Compound 4, half-maximal inhibitory concentration: > 25000 nM
Compound 4: no number, only a limit; the forecaster's own chance of this, stated with the estimate: 70%; the middle value lies beyond the limit too.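

Compound 2 and compound 4 each give only a limit in this assay, and no step between them can be read: the limit of > 25000 nM in this assay, at which 2 of the 4 values shown sit.

The compounds shown leave open whether hydrogen in place of chloro changes the number at all on the core of compound 2.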